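Swapping the aryl group on the shared core of compound 2

The compounds below may be only part of what the source reports. "The series", "measured", "known", "first", "only" and "open" are said of these compounds alone.

Measured so far:
compound 1 `CCOc1ncc(-c2nc(C(F)(F)F)sc2N2CCN(C(=O)Cn3cnc4cccnc43)[C@H](C)C2)cn1`: 48 nM
compound 2 `CCc1ncc(-c2nc(C(F)(F)F)sc2N2CCN(C(=O)Cn3nc(C)nc3C)[C@H](C)C2)cn1`: 567 nM

In an assay on blood for inhibition of C-X-C chemokine receptor type 3 (Homo sapiens), with a stated time of 30 min (a lower number here means a stronger inhibitor, a higher number a weaker inhibitor), compound 1 gives 48 nM, while compound 2 gives 567 nM, the higher of the two numbers. Compound 2 and compound 1 differ in more than one place, so no single structural cause for that gap can be drawn from these two values alone.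

Compound 3 `Cc1nc(C)n(CC(=O)N2CCN(c3sc(C(F)(F)F)nc3-c3ccc(C(F)(F)F)nc3)C[C@H]2C)n1` keeps the amide part of compound 2 and changes only the aryl group attached to the five-membered ring: 6-(trifluoromethyl)pyridin-3-yl in place of 2-ethylpyrimidin-5-yl on an aromatic carbon. Because compound 2 stands at 567 nM, the weaker end of what has been measured, the expectation for compound 3 is a modest move toward a lower number in this assay rather than a large one, with a real chance of no change beyond the scatter. The estimated step is a 1.9-fold lower number from compound 2 to compound 3 (0.28 log units; within the scatter). Compound 3 is expected to give about 300 nM, within a range from 80 nM to 1200 nM.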

Compound 3, half-maximal inhibitory concentration: 860 nM
For compound 3 the middle estimate is 2.9-fold (0.46 log units) below the measured one; low and high end bracket the measured number.
By their numbers in this assay, from the lowest: compound 1; then compounds 2 and 3 (each within the scatter of the next).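

In this assay, putting 6-(trifluoromethyl)pyridin-3-yl in place of 2-ethylpyrimidin-5-yl gives a 1.5-fold higher number from compound 2 to compound 3 (0.18 log units; within the scatter), so the two compounds cannot be told apart in this measurement. This is the first comparison shown that changes only this position, the aromatic carbon of the five-membered ring, while the amide part stays fixed. With that amide part, the swap from a ring with 2 hetero atoms to one with 1 hetero atom and an added trifluoromethyl group leaves the result within the usual scatter, and no measured evidence here explains this outcome.

Going by these compounds, compound 1, at 48 nM, differs from compound 2 and compound 3 in more than one place, so it remains unknown whether the same aryl swap would also fall within the scatter when paired with the amide part of compound 1. On these data alone, it also remains open whether a different group at this position, such as a plain phenyl ring or a pyrimidine carrying an amine, would shift the number beyond the scatter.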